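Sulfonamide variation at the thiourea-linked quinoline series

This account rests on a few compounds, and the source may have more. Where it says the series, first, only, none or still open, it means among the compounds named here.

Measured compounds:
- compound 1 `Nc1ccc(S(=O)(=O)Nc2ccnc3cc(C(F)(F)F)ccc23)cc1` — in a functional assay on LoVo cells (Homo sapiens) for antiproliferative activity, read by sulforhodamine B assay, with a stated time of 48 h (a higher number here means a weaker inhibitor, a lower number a stronger inhibitor), compound 1 gives 53700 nM
- compound 2 `N=C(N)NS(=O)(=O)c1ccc(N/C(S)=N\c2ccnc3cc(C(F)(F)F)ccc23)cc1` — compound 2 gives 23900 nM
- compound 3 `Cc1cc(NS(=O)(=O)c2ccc(N/C(S)=N\c3ccnc4cc(C(F)(F)F)ccc34)cc2)on1` — compound 3 gives "not active" (no number reported)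

Compound 3 stands at the bottom of what is shown: it is the one member of the set for which no concentration could be quoted, whereas compound 1 and compound 2 both return weak but countable values. Compound 4 `O=S(=O)(Nc1ncccn1)c1ccc(N/C(S)=N\c2ccnc3cc(C(F)(F)F)ccc23)cc1` keeps the whole of the remaining molecule and changes only the group on the sulfonamide nitrogen: pyrimidin-2-yl in place of 3-methyl-1,2-oxazol-5-yl on a sulfonamide nitrogen. Among the compounds with values here, no measured pair shows what such a swap does, so the size of the move is open. The nearest guide is the spread between compound 1 and compound 2, both weak, and the absence of a number for compound 3; nothing in this set points toward a strong inhibitor. The expectation for compound 4 is therefore a weak value near the region of compounds 1 and 2, with a real chance that again only a limit is reported; the estimate is 40000 nM, ranging from 12000 nM to 150000 nM.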

Compound 4, half-maximal inhibitory concentration: 34700 nM
Estimate against measurement, compound 4: 1.2-fold (0.06 log units) above, and the stated range covers the measured number.
By their numbers in this assay, from the lowest: compounds 2, 4 and 1 (each within the scatter of the next, the first and the last beyond it).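

In this assay compound 4 gives 34700 nM, so a sulfonamide nitrogen carrying pyrimidin-2-yl still returns a countable value, whereas compound 3, with 3-methyl-1,2-oxazol-5-yl in that place, has no number. Within the data shown here, the first measured step at this position does not separate a six-membered aromatic ring from a ring-free group: a 1.5-fold higher number from compound 2 to compound 4 (0.16 log units; within the scatter). Nothing available here bears on the reason for either result.

Still open, on these data alone, is whether any group on this nitrogen moves the number far from the values of compound 2 and compound 4, since both remain in the same weak region. A bare sulfonamide nitrogen, a simple methyl group or an unsubstituted phenyl ring would show whether a hetero-aromatic ring is needed here at all.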